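This account rests on a few compounds, and the source may have more. Where it says the series, first, only, none or still open, it means among the compounds named here.

Measured compounds:
- compound 1 `Cc1cc(C(=O)NN2CCCCC2)nn1Cc1cc(Cl)ccc1OCC(C)C`: 200 nM
- compound 2 `Cc1cc(NC(=O)C2CCCC2)nn1Cc1cc(Cl)ccc1OCc1ccccc1`: 15.9 nM
- compound 3 `Cc1cc(NC(=O)C2CCCC2)nn1Cc1cc(Cl)ccc1OCC(C)C`: 25.1 nM

All three were tested in an assay on CHO-K1 cells for displacement of a labelled ligand from prostaglandin E2 receptor EP1 subtype (Homo sapiens); a higher number here means a weaker inhibitor, a lower number a stronger inhibitor. Compound 3 sits second highest of the three numbers: it lies close to compound 2, with a 1.6-fold higher number from compound 2 to compound 3 (0.20 log units; within the scatter), and well apart from compound 1, with an 8.0-fold lower number from compound 1 to compound 3 (0.90 log units; beyond the scatter).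

Compound 4 `Cc1cc(NC(=O)OC2CCOCC2)nn1Cc1cc(Cl)ccc1OCC(C)C` is the next compound. It differs from compound 3 in one place: (oxan-4-yl)oxy in place of cyclopentyl on a carbonyl carbon. The amide group that carries this change is the same part of the molecule that was altered between compound 1 and compound 3, and that alteration moved the number beyond the scatter, so this region is known to matter. The step from compound 2 to compound 3 concerns the other end of the molecule and does not bear on the present change. Among the compounds with values here, no measured pair shows what replacing cyclopentyl with (oxan-4-yl)oxy on the carbonyl carbon does, so the direction is uncertain; a modest move toward a higher number is expected, since the known change at this position weakened binding when it departed from the cyclopentylcarbonyl arrangement. Compound 4 is therefore expected to give 50 nM, within 15 nM to 250 nM, an expected step of a 2.0-fold higher number from compound 3 to compound 4 (0.30 log units; within the scatter).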

Compound 4, half-maximal inhibitory concentration in the prostaglandin E2 receptor EP1 subtype assay: 63.1 nM
For compound 4 the middle estimate is 1.3-fold (0.10 log units) below the measured one; the measured number falls inside the stated range.
By their numbers in the prostaglandin E2 receptor EP1 subtype assay, from the lowest: compounds 2 and 3 (each within the scatter of the next); then compound 4; then compound 1.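

In the prostaglandin E2 receptor EP1 subtype assay, a 2.5-fold higher number from compound 3 to compound 4 (0.40 log units; beyond the scatter). The earlier change at this end of the molecule rearranged the whole amide link, whereas here the carbonyl and its amide-type nitrogen stay in place, and changing only the group on the carbonyl carbon moves the number beyond the scatter. The lipophilicity reading adds a second side to this change, though only in part. In a physicochemical assay for lipophilicity, at pH 7.4 (a lower number here means a more polar compound, a higher number a more lipophilic compound), compound 4 gives 3.4, and the step reads a number at least 0.30 log units lower from compound 3 to compound 4 (that floor lies within the scatter). In the physicochemical assay compound 3 gives > 3.7 as a limit, which is not a number: the limit of > 3.7 in the physicochemical assay, at which 1 of the 2 values shown sits.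

The linking oxygen and the six-membered ring enter together in this one change, and the two compounds cannot show how much of either step belongs to each part. Cyclopentyloxy on the same carbonyl carbon, or an oxan-4-yl group bound directly to it, would separate the two, and an amine such as piperidin-4-ylamino in that place would test a different kind of group there.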